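This account rests on a few compounds, and the source may have more. Where it says the series, first, only, none or still open, it means among the compounds named here.

Measured in an ADME assay on EA.hy 926 cells (Homo sapiens) for inhibition, read by sulforhodamine B assay, with a stated time of 72 h; a higher number here means a weaker inhibitor, a lower number a stronger inhibitor:
- Compound 1 `CCC(C)NC(=C\C(=O)/C=C/c1ccc(O)c(OC)c1)/C=C/c1ccc(O)c(OC)c1`: > 25000 nM
- Compound 2 `CC(C)CNC(=C\C(=O)/C=C/c1ccc(O)cc1)/C=C/c1ccc(O)cc1`: > 25000 nM
- Compound 3 `COc1cc(/C=C/C(=O)CC(=O)/C=C/c2ccc(OC(C)=O)c(OC)c2)ccc1OC(C)=O`: > 25000 nM

Each of these three entries is a limit of the assay and not a number. Compound 1 stands with the rest of the set, at the limit of > 25000 nM in this assay, at which 3 of the 3 values shown sit. For the measured compounds named here, no step between measured compounds is available, so the data give no measured size for any structural change, and these three compounds cannot be ranked against one another.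

The next compound to be tested is compound 4 `COc1cc(/C=C/C(=O)/C=C(/C=C/c2ccc(O)c(OC)c2)NC2CCCCC2)ccc1O`, which keeps the core of compound 1 and changes a single group: cyclohexyl in place of sec-butyl on an amine nitrogen. In words, cyclohexyl stands in place of sec-butyl on an amine nitrogen. The only anchor for an expectation is compound 1, with its limit of > 25000 nM. A single change of this kind is not expected to produce a large jump in this assay, and any shift should be a modest one towards stronger inhibition. The expected change is an at least 1.2-fold lower number from compound 1 to compound 4 (0.09 log units; that floor lies within the scatter), and a reading that again gives only a limit would be no surprise. For compound 4 the estimated half-maximal inhibitory concentration is 20000 nM, with an expected range of 7000 nM to 35000 nM.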

Compound 4, half-maximal inhibitory concentration: > 25000 nM
Compound 4: only a limit was reported (the forecaster's own chance of this, stated with the estimate: 60%); middle value at least 1.2-fold (0.09 log units) from the limit.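

The change from compound 1 to compound 4, cyclohexyl in place of sec-butyl on an amine nitrogen, gives no readable step, because both readings are limits of the assay and not numbers: the limit of > 25000 nM in this assay, at which 4 of the 4 values shown sit. The compounds shown leave open how strongly any of them inhibits in this assay, and whether this change of group alters that at all.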